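Lengthening the Propanoyl Chain of Compound 3

The source may hold more compounds than are shown below. What is called first, only, known or untested is meant among the compounds shown, and "the series" means these compounds.

In a functional assay on HepG2 cells (Homo sapiens) for cytotoxicity, read by MTT assay (a lower number here means a stronger inhibitor, a higher number a weaker inhibitor), compound 3 `CCC(=O)Oc1cc(/C=C/C(=O)c2ccc(OC)c3c2OC(C)(C)C=C3)ccc1OC` gives 90 nM, and it is the only one of the three measured compounds with an actual number. Compound 1 `C#CCOc1cc(/C=C/C(=O)c2ccc(OC)c3c2OC(C)(C)C=C3)ccc1OC` reads > 10000 nM, which is a limit of the assay and not a number. Compound 2 `COc1ccc(/C=C/C(=O)c2ccc(OC)c3c2OC(C)(C)C=C3)cc1OCCO` reads > 10000 nM, which is also a limit.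

Compound 4 `CCCCC(=O)Oc1cc(/C=C/C(=O)c2ccc(OC)c3c2OC(C)(C)C=C3)ccc1OC` differs from compound 3 by a single change: ethyl in place of hydrogen on a saturated chain carbon, two bonds along the chain from a carbonyl carbon. Read one bond further out, this is propanoyl to butylcarbonyl.

Two measured steps involve the propanoyl group. Putting propanoyl in place of propargyl on an oxygen on an aromatic ring gave an at least 110-fold lower number from compound 1 to compound 3 (2.04 log units; beyond the scatter). Putting propanoyl in place of 2-hydroxyethyl on that oxygen gave an at least 110-fold lower number from compound 2 to compound 3 (2.04 log units; beyond the scatter). Both steps are large, but each exchanges the whole group on the oxygen. Within the data shown here, compound 4 keeps the carbonyl and changes only the chain, and no measured pair tests that kind of change, so these steps offer only indirect guidance.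

The step expected in this assay is therefore modest, and the estimate is a 1.7-fold higher number from compound 3 to compound 4 (0.22 log units; within the scatter). For compound 4, the estimated value is 150 nM, with an expected range from 30 nM to 1500 nM.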

Compound 4, half-maximal inhibitory concentration: 100 nM
Estimate against measurement, compound 4: 1.5-fold (0.18 log units) above, and the stated range covers the measured number.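

In this assay, ethyl in place of hydrogen on a saturated chain carbon, two bonds along the chain from a carbonyl carbon, gives a 1.1-fold higher number from compound 3 to compound 4 (0.05 log units; within the scatter). The earlier steps shown here exchanged the whole group on the oxygen, whereas this pair keeps the carbonyl and changes only the chain, and it shows that going from propanoyl to butylcarbonyl does not move the number beyond the usual scatter. Butylcarbonyl also stands well apart from the two groups without a carbonyl, with an at least 100-fold lower number from compound 2 to compound 4 (2.00 log units; beyond the scatter) and an at least 100-fold lower number from compound 1 to compound 4 (2.00 log units; beyond the scatter), and each of these steps starts from a limit of the assay and not from a number.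

This single step says nothing about how far the chain can go, so a longer chain, a branched chain, or a chain ending in an amine or a carboxylic acid remains an open case. Going by these compounds, it also remains open whether the carbonyl itself accounts for the large steps, as compound 1 and compound 2 differ from compound 4 in the whole group on the oxygen, and an ethyl or butyl group on that oxygen would be the closer comparison.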